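The source may hold more compounds than are shown below. What is called first, only, known or untested is meant among the compounds shown, and "the series" means these compounds.

Working notes on the shared core. Compound 1 `COc1c(Cl)ccc2c1CCC2c1ncc[nH]1` gives in a functional assay on CHO cells for agonist activity at Alpha-1B adrenergic receptor (Homo sapiens), read by FLIPR and calcium flux (on this read-out higher numbers stand for an effect only at larger amounts of compound and lower numbers for an effect already at smaller amounts), only a limit of the assay, > 10000 nM. Compound 2 `CCS(=O)(=O)Nc1cccc2c1CCC2c1ncc[nH]1` likewise reaches only a limit, > 10000 nM. Compound 3 `Cc1oncc1-c1cccc2c1CCC2c1ncc[nH]1` stands at a limit as well, > 10000 nM. Within the data shown here, the single measured step, a step that the two limits leave unreadable from compound 2 to compound 3, cannot be read, since every value sits at the limit of > 10000 nM in this assay, at which 3 of the 3 values shown sit. Compound 4 `c1cc(-c2ccn[nH]2)c2c(c1)C(c1ncc[nH]1)CC2` differs from compound 3 by 1H-pyrazol-5-yl in place of 5-methyl-1,2-oxazol-4-yl on an aromatic carbon. No readable step bears on this change, and all three measured compounds sit at the same limit, so no step beyond the scatter is expected. The expected step from compound 3 to compound 4 is a number no higher from compound 3 to compound 4 (the limit leaves the size open). Compound 4 is estimated at 10000 nM, with a range from 3000 nM to 30000 nM, most likely reported again as a limit.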

Compound 4, half-maximal effective concentration: 600 nM
Estimate against measurement, compound 4: 17-fold (1.22 log units) above; measured number outside the range, below it.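

In this assay, this aromatic carbon, ortho to a fused ring, can carry a group that gives a readable value: 1H-pyrazol-5-yl in place of 5-methyl-1,2-oxazol-4-yl gives an at least 16-fold lower number from compound 3 to compound 4 (1.22 log units; beyond the scatter). 1H-pyrazol-5-yl in place of (ethylsulfonyl)amino gives an at least 16-fold lower number from compound 2 to compound 4 (1.22 log units; beyond the scatter). Only compound 4 leaves the limit among the compounds shown: the limit of > 10000 nM in this assay, at which 3 of the 4 values shown sit.

Going by these compounds, whether the step follows the hydrogen-bond donor counted on 1H-pyrazol-5-yl stays open. A methyl group on the pyrazole nitrogen, or a plain amine on the same carbon, would bear on this.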